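The source may report more compounds than this note shows. Statements on the series, on what has been measured and on what is new or still open speak of the compounds shown alone.

Measured in an ADME assay on LLC-MK2 cells (Macaca mulatta) for cytotoxicity, read by spectrophotometry and crystal violet staining, with a stated time of 4 days; a lower number here means that less compound is tolerated, a higher number that more compound is tolerated:

Compound 1 `CC(C)n1ncc2c(C(=O)Nc3ccccc3F)cc(-c3cccnc3)nc21`: 50000 nM
Compound 2 `CNS(=O)(=O)c1cccc(NC(=O)c2cc(-c3cccs3)nc3c2cnn3C(C)C)c1`: 25000 nM
Compound 3 `CC(C)n1ncc2c(C(=O)Nc3ccncn3)cc(-c3cccs3)nc21`: 50000 nM

Compound 1 stands level with compound 3 at the digits shown, and these two carry the highest numbers of the three. Compound 2 sits nearest to the bottom, but its gap to compound 1 lies within the scatter of repeated measurements, so no real difference can be claimed among the three. Compound 4 `CC(C)n1ncc2c(C(=O)Nc3ccccc3F)cc(-c3ccccn3)nc21` keeps every atom of compound 1 and changes only one thing: pyridin-2-yl in place of pyridin-3-yl on an aromatic carbon. Among the measured compounds shown here, no measured pair here shows what this change does, so in this assay a step of no size beyond the scatter is expected, in either direction. Compound 4 is therefore estimated at 50000 nM, with a range from 25000 nM to 100000 nM. That estimate means a step of no change at the digits printed from compound 1 to compound 4 (within the scatter), expected to be flat.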

Compound 4, half-maximal cytotoxic concentration: 100000 nM
Beside the measured number, compound 4's estimate is 2.0-fold (0.30 log units) below it; low and high end bracket the measured number.
By their numbers in this assay, from the lowest: compounds 2, 1, 3 and 4 (each within the scatter of the next, the first and the last beyond it).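

In this assay, pyridin-2-yl in place of pyridin-3-yl gives a 2.0-fold higher number from compound 1 to compound 4 (0.30 log units; within the scatter). This first measured pair at this position therefore shows that moving the ring nitrogen of the pyridine, with the same atoms and the rest of the molecule unchanged, makes no difference that can be told from the scatter. Among the compounds shown here, no evidence about this step is at hand.

The compounds shown leave open how this position would respond to a quite different group, such as a carboxylic acid or an amine, in place of the pyridine ring. Pyridin-4-yl also remains open.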